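The compounds below may be only part of what the source reports. "The series", "measured", "known", "first", "only" and "open" are said of these compounds alone.

So far two compounds that share one core have been measured, compound 1 `CC[C@H](C)[C@@H](O)C(=O)O[C@@H](C(=O)O[C@@H](C(=O)O[C@@H](C(=O)O[C@@H](C(=O)OC[C@@H](O)[C@@H](O)[C@H](O)CO)[C@@H](C)CC)[C@@H](C)CC)[C@@H](C)CC)[C@@H](C)CC` and compound 2 `CC[C@H](C)[C@@H](O)C(=O)O[C@@H](C(=O)O[C@@H](C(=O)O[C@@H](C(=O)O[C@@H](C(=O)O[C@H](CO)[C@@H](O)[C@H](O)[C@H](O)CO)[C@@H](C)CC)[C@@H](C)CC)[C@@H](C)CC)[C@@H](C)CC`. In a functional assay on MCF7 cells (Homo sapiens) for cytotoxicity, read by MTT assay, with a stated time of 24 h (on this read-out higher numbers stand for weaker inhibition and lower numbers for stronger inhibition), compound 1 gives 15600 nM and compound 2 gives 18300 nM. These two values lie within the scatter of each other, so compound 2 stands level with compound 1.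

Compound 3 `CC[C@H](C)[C@@H](O)C(=O)O[C@@H](C(=O)O[C@@H](C(=O)O[C@@H](C(=O)O[C@@H](C(=O)OC[C@@H](O)[C@@H](O)[C@H](O)[C@H](O)CO)[C@@H](C)CC)[C@@H](C)CC)[C@@H](C)CC)[C@@H](C)CC` keeps the shared core and differs from compound 2 at one place: 2,3,4,5,6-pentahydroxyhexyl in place of 2,3,4,5-tetrahydroxy-1-(hydroxymethyl)pentyl on an oxygen next to a carbonyl group. In words, 2,3,4,5,6-pentahydroxyhexyl sits in place of 2,3,4,5-tetrahydroxy-1-(hydroxymethyl)pentyl on an oxygen next to a carbonyl group. The same atoms are simply joined differently.

Among the measured compounds shown here, only one measured step bears on this swap, and it concerns the same oxygen: 2,3,4,5-tetrahydroxy-1-(hydroxymethyl)pentyl in place of 2,3,4,5-tetrahydroxypentyl gave a 1.2-fold higher number from compound 1 to compound 2 (0.07 log units; within the scatter). A single step sets no rule, but it offers no sign that a change at this oxygen moves the number much. No shift beyond the scatter is therefore expected in this assay, and no direction can be argued from the data. The expected step is a 1.1-fold lower number from compound 2 to compound 3 (0.03 log units; within the scatter). For compound 3 the estimated value is 17000 nM, with an expected range from 9000 nM to 32000 nM.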

Compound 3, half-maximal inhibitory concentration: 24300 nM
The estimate for compound 3 lay 1.4-fold (0.16 log units) below the measured number, and the stated range covers the measured number.
By their numbers in this assay, from the lowest: compounds 1, 2 and 3 (each within the scatter of the next).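

In this assay, the atoms of the 2,3,4,5-tetrahydroxy-1-(hydroxymethyl)pentyl group can be rejoined as 2,3,4,5,6-pentahydroxyhexyl on an oxygen next to a carbonyl group, and the result is a 1.3-fold higher number from compound 2 to compound 3 (0.12 log units; within the scatter), so this rearrangement of the same atoms leaves the number level. The other new comparison tests a change in size at the same place, hydroxymethyl in place of hydrogen on a saturated chain carbon bound to an oxygen on a saturated carbon and a saturated chain carbon, and gives a 1.6-fold higher number from compound 1 to compound 3 (0.19 log units; within the scatter), so all three compounds now stand level, and neither this added group nor the way the atoms are joined separates them. No independent measurement is available that could explain this flat picture.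

Every group shown on this oxygen is a hydroxyl-bearing chain without a ring, so it remains open whether an amine, a carboxylic acid or a plain hexyl chain there would move the number beyond the scatter. Going by these compounds, it also remains open whether changes elsewhere on the shared core would matter more than those at this oxygen.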